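Swapping the aryl group on a pyrazole sulfonamide

A few compounds are considered here, and "the series" means these few. Any claim that something is new, unique, unknown or untested is made for them only; others in the source may bear on it.

Measured compounds:
compound 1 `O=C1c2[nH]nc(NS(=O)(=O)c3ccc4ccccc4c3)c2CCN1CC1CCNCC1` gives 310 nM in a functional assay on HeLa cells for antagonist activity at 5-hydroxytryptamine receptor 6 (Homo sapiens), read by HTRF and cAMP accumulation, with stated times of 10 min and 30 min; on this read-out lower numbers stand for stronger inhibition and higher numbers for weaker inhibition
compound 2 `CC(C)Cc1cc(CNS(=O)(=O)c2ccc(C(C)(C)C)cc2)nn1-c1ccccc1` gives 8780 nM in this assay

Of the two numbers in hand, compound 2 stands at the higher one; compound 1 sits well below it, and that gap lies beyond the scatter of repeated measurements. Among the compounds with values here, no step between measured compounds that differ in a single place is available, so nothing tells how this assay responds to a change on the sulfonyl sulfur.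

Compound 3 `Cc1c(Cl)cccc1S(=O)(=O)NCc1cc(CC(C)C)n(-c2ccccc2)n1` is the unmeasured analogue of compound 2. The change is 3-chloro-2-methylphenyl in place of 4-(tert-butyl)phenyl on a sulfonyl sulfur. Within the data shown here, with no comparable step recorded, the expectation rests on compound 2 alone, and no strong movement in either direction can be argued beyond the scatter; the estimated step is a 1.3-fold lower number from compound 2 to compound 3 (0.10 log units; within the scatter). Compound 3 is therefore expected to give about 7000 nM, within a range from 2000 nM to 25000 nM.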

Compound 3, half-maximal inhibitory concentration: 4010 nM
Estimate against measurement, compound 3: 1.7-fold (0.24 log units) above; the range from low to high includes it.
By their numbers in this assay, from the lowest: compound 1; then compound 3; then compound 2.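

In this assay the sulfonyl sulfur now has its first readable step: 3-chloro-2-methylphenyl in place of 4-(tert-butyl)phenyl gives a 2.2-fold lower number from compound 2 to compound 3 (0.34 log units; beyond the scatter), a modest change. This shows that the number responds to the aryl group at this position, although the exchange replaces several features at once, so the separate shares of the chlorine, the methyl and the loss of the tert-butyl group cannot be told apart. Nothing available accounts for the step.

From the compounds shown here alone, whether a methoxy group or a carboxylic acid on this aryl ring, or an amine-bearing chain in its place, would move the number further remains open. Going by these compounds, it is also open whether the same exchange would produce a similar step on the core of compound 1.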